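A few compounds are considered here, and "the series" means these few. Any claim that something is new, unique, unknown or untested is made for them only; others in the source may bear on it.

Two compounds of the series have been run in a functional assay on the whole organism with Rattus norvegicus as the target, at a dose of 20 mg/kg by the oral route; on this read-out lower numbers stand for less inhibition and higher numbers for more inhibition at the one dose given (going by the name of the read-out). Compound 1 `Cc1cccc2c1CC/C2=C\C(=O)NC1CC1` gives 15% in this assay. Compound 2 `O=C(/C=C1\CCc2ccc(F)cc21)NCC1CC1` gives 0% in this assay, the lowest of the two numbers; the nearest neighbour, compound 1, stands higher by a margin that lies beyond the usual scatter. Among the compounds with values here, no pair of these two differs in only one place, so no single-change step is available to lean on.

Compound 3 `O=C(/C=C1\CCc2ccc(F)cc21)NCCO` has not yet been measured. Its difference from compound 2 is hydroxymethyl in place of cyclopropyl on a saturated chain carbon bound to an amide-type nitrogen. Within the data shown here, no measured step of this kind exists, so nothing here shows whether the change matters. With compound 2 already at the floor of the read-out, the step from compound 2 to compound 3 is expected to be a number 5 percentage points higher from compound 2 to compound 3 (within the scatter), that is, none beyond the scatter. For compound 3 the expected value in this assay is 5%. The expected range for compound 3 is estimated to run from 0% to 20%.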

Compound 3, a percentage reported as inhibition, in the whole organism at one dose (the size of the read-out at that dose, not a potency): 42%
For compound 3 the middle estimate is 37 percentage points below the measured one; the whole stated range lies below it.
By their numbers in this assay, from the lowest: compound 2; then compound 1; then compound 3.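

In this assay, within the data shown here, hydroxymethyl in place of cyclopropyl on a saturated chain carbon bound to an amide-type nitrogen gives a number 42 percentage points higher from compound 2 to compound 3 (beyond the scatter), the only single-change step so far. The read-out therefore responds to the group at this position, and with the core shared by compound 2 and compound 3 unchanged, the floor value of compound 2 cannot be a feature of that core alone. No measurement shown here accounts for the size of this step.

Still open, from the compounds shown here alone, is whether the rise tracks the entering hydroxymethyl or the departing cyclopropyl ring; a 2-methoxyethyl group, a plain propyl chain or a 3-hydroxypropyl chain at this position would help separate the two. Also open, going by these compounds, is whether the same change holds on the core of compound 1.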